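Aryl variation on the shared core, cytotoxicity

The source may report more compounds than this note shows. Statements on the series, on what has been measured and on what is new or still open speak of the compounds shown alone.

Compound 1 `COc1ccccc1/C=c1/[nH]c(=O)/c(=C\c2ccccc2OC)n(C)c1=O` has no result in a functional assay on MOLT-4 cells (Homo sapiens) for cytotoxicity, read by CCK-8 assay, with a stated time of 72 h (a higher number here means a weaker inhibitor, a lower number a stronger inhibitor), its entry being "not determined" (no result reported). Compound 2 `C=CCn1c(=O)/c(=C\c2cccc(F)c2)[nH]c(=O)/c1=C\c1ccccc1OC` gives 6500 nM in this assay, and compound 3 `C=CCn1c(=O)/c(=C\c2ccccc2Cl)[nH]c(=O)/c1=C\c1ccccc1OC` gives 4400 nM. Of the two numbers available, compound 2 sits at the upper one, but the step of a 1.5-fold lower number from compound 2 to compound 3 (0.17 log units; within the scatter) is within the scatter, so the two cannot be separated.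

Compound 4 `C=CCn1c(=O)/c(=C\c2ccc(Cl)c(Cl)c2)[nH]c(=O)/c1=C\c1ccccc1OC` is the next entry. Relative to compound 2 the change is 3,4-dichlorophenyl in place of 3-fluorophenyl on a double-bonded chain carbon bound to an aromatic carbon. Going by the values given here, the only measured step that bears on this is the exchange of one substituted phenyl for another at the same place, a 1.5-fold lower number from compound 2 to compound 3 (0.17 log units; within the scatter), which stayed within the scatter. A change of aryl substituent at this position therefore has not yet produced a shift beyond the scatter, and a similar outcome is expected for compound 4, with at most a small move toward a lower number. The step of a 1.4-fold lower number from compound 2 to compound 4 (0.16 log units; within the scatter) is the expected size. Compound 4 is estimated at 4500 nM in this assay, within a range of 1800 nM to 11000 nM.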

Compound 4, half-maximal inhibitory concentration: "not active" (no number reported)
Compound 4: no number reported, and the estimate cannot be compared.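

In this assay, going by these compounds alone, compound 4 gives "not active" (no number reported) and so offers no number, which means no step from compound 2 or compound 3 to compound 4 can be read. The compounds shown leave open how 3,4-dichlorophenyl compares numerically with 3-fluorophenyl at this place. No measurement shown bears on this entry.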